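From 6-chloropyridin-3-yl to 2-chloropyridin-3-yl

The compounds below may be only part of what the source reports. "The series", "measured", "known", "first", "only" and "open" are said of these compounds alone.

Measured so far in a functional assay on WM 266-4 cells (Homo sapiens) for antiproliferative activity, read by MTT assay, with a stated time of 24 h; a higher number here means a weaker inhibitor of growth, a lower number a stronger inhibitor of growth
- compound 1 `O=C(c1cccnc1Cl)N1N=C(c2ccc(Cl)cc2)CC1c1ccc(OCc2ccccc2)cc1` gives 7710 nM
- compound 2 `O=C(c1ccc(Cl)nc1)N1N=C(c2ccc(Cl)cc2)CC1c1ccc(Br)cc1` gives 9870 nM

Within the data shown here, with only two numbers available, compound 2 cannot be ranked, since its value and that of compound 1 lie within the usual scatter of each other. Compound 3 `O=C(c1cccnc1Cl)N1N=C(c2ccc(Cl)cc2)CC1c1ccc(Br)cc1` is built like compound 2, but with 2-chloropyridin-3-yl in place of 6-chloropyridin-3-yl on a carbonyl carbon. The same atoms are simply joined differently. Among the measured compounds shown here, no measured pair shows this change alone. Compound 1 does carry the entering group and gives 7710 nM, but it also differs elsewhere, so it offers only indirect guidance. The expected result is a 1.2-fold lower number from compound 2 to compound 3 (0.06 log units; within the scatter), an estimated change that stays within the scatter, with no firm direction. In this assay compound 3 is estimated at 8500 nM (expected range 3500 nM to 20000 nM).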

Compound 3, concentration for 50% growth inhibition: 7450 nM
Estimate against measurement, compound 3: 1.1-fold (0.06 log units) above, and the stated range covers the measured number.
By their numbers in this assay, from the lowest: compounds 3, 1 and 2 (each within the scatter of the next).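

In this assay, 2-chloropyridin-3-yl in place of 6-chloropyridin-3-yl on a carbonyl carbon gives a 1.3-fold lower number from compound 2 to compound 3 (0.12 log units; within the scatter) in this first direct test of the change, so joining the same atoms differently here produces no difference that can be told from the scatter. Compound 3 also provides a single-place comparison for bromo in place of benzyloxy on an aromatic carbon, which gives a 1.0-fold lower number from compound 1 to compound 3 (0.01 log units; within the scatter) and leaves those two groups equally unresolved in this set. No supporting data bear on the reason for either result.

From the compounds shown here alone, it remains open whether an amine or a methoxy group in place of the chlorine on the pyridine ring would move the number beyond the scatter. The same question stands for a carboxylic acid in place of the bromo group.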